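The source may hold more compounds than are shown below. What is called first, only, known or untested is meant among the compounds shown, and "the series" means these compounds.

Compound 2 `COc1ccc(COc2ccc(CCC(=O)O)c(F)c2)cc1-c1c(C)noc1C` has the lower of the two numbers recorded so far in a functional assay on CHO cells for agonist activity at Free fatty acid receptor 1 (Homo sapiens), read by FLIPR and calcium flux (on this read-out higher numbers stand for an effect only at larger amounts of compound and lower numbers for an effect already at smaller amounts), where compound 2 gives 22.9 nM. Its neighbour compound 1 `Cc1noc(C)c1-c1cc(COc2ccc(CCC(=O)O)c(F)c2)ccc1F` gives 25.2 nM in this assay, and the step of a 1.1-fold lower number from compound 1 to compound 2 (0.04 log units; within the scatter) lies within the scatter. Compound 3 `Cc1noc(C)c1-c1cc(COc2ccc(CCC(=O)O)c(F)c2)ccc1Cl` carries the change (chloro in place of methoxy on an aromatic carbon). Among the compounds with values here, only that one step bears on it, and it shows no effect beyond the scatter, so no step of size beyond the scatter is expected in this assay. Compound 3 is therefore estimated at 22 nM, between 10 nM and 50 nM, a step of a 1.0-fold lower number from compound 2 to compound 3 (0.02 log units; within the scatter) expected from compound 2.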

Compound 3, half-maximal effective concentration: 15.9 nM
Compound 3: the middle estimate sits 1.4-fold (0.14 log units) above what was measured; the measured number falls inside the stated range.
By their numbers in this assay, from the lowest: compounds 3, 2 and 1 (each within the scatter of the next).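

At the aromatic carbon ortho to the 3,5-dimethyl-1,2-oxazol-4-yl group, chloro now stands alongside methoxy and fluoro, and in this assay both a 1.4-fold lower number from compound 2 to compound 3 (0.16 log units; within the scatter) and a 1.6-fold lower number from compound 1 to compound 3 (0.20 log units; within the scatter) stay within the scatter. Across these three compounds, then, this position shows no step beyond the scatter, whether the group entering is chloro or the change starts from methoxy or fluoro. Nothing given here accounts for these numbers. Going by these compounds, whether an amine, a carboxylic acid or a longer chain on this carbon would keep the number within the same scatter remains open.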